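Anilide in Place of Ester on a Weakly Active Core

A few compounds are considered here, and "the series" means these few. Any claim that something is new, unique, unknown or untested is made for them only; others in the source may bear on it.

Within the data shown here, compound 1 `CCOC(=O)C1=C(C)NC(=O)NC1c1cn(-c2ccccc2)nc1-c1ccccc1` gives 60800 nM in a functional assay on MCF7 cells (Homo sapiens) for inhibition, read by sulforhodamine B assay, with a stated time of 24 h (on this read-out lower numbers stand for stronger inhibition of growth and higher numbers for weaker inhibition of growth), and holds the highest of the two numbers measured so far. Compound 2 `CCOC(=O)C1=C(C)NC(=S)NC1c1cn(-c2ccccc2)nc1-c1ccccc1` gives 42000 nM in this assay, and the two values lie within the usual scatter of each other. Compound 3 `CC1=C(C(=O)Nc2ccccc2)C(c2cn(-c3ccccc3)nc2-c2ccccc2)NC(=O)N1` differs from compound 1 by anilino in place of ethoxy on a carbonyl carbon. Among the measured compounds shown here, no measured pair shows this change, so the outlook rests on compound 1 alone. The expected change, a 1.4-fold lower number from compound 1 to compound 3 (0.13 log units; within the scatter), is small, with no direction beyond the scatter. Compound 3 is estimated to give 45000 nM, within 12000 nM to 150000 nM, in this assay.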

Compound 3, concentration for 50% growth inhibition: 80600 nM
The estimate for compound 3 lay 1.8-fold (0.25 log units) below the measured number; the measured number falls inside the stated range.
By their numbers in this assay, from the lowest: compounds 2, 1 and 3 (each within the scatter of the next).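

In this assay, anilino in place of ethoxy on a carbonyl carbon gives a 1.3-fold higher number from compound 1 to compound 3 (0.12 log units; within the scatter), a step within the scatter. This position therefore takes the larger anilino group, with its six-membered aromatic ring and hydrogen-bond donor, without a change beyond the scatter, although this single step shows no gain. Nothing measured here bears on why the number stays within the scatter. As far as these compounds go, it remains open whether a carboxylic acid or a methylamino group on this carbonyl carbon would move the number beyond the scatter. From the compounds shown here alone, the same change made on compound 2 also remains open.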